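One Added Methoxy on a Weak Inhibitor

A few compounds are considered here, and "the series" means these few. Any claim that something is new, unique, unknown or untested is made for them only; others in the source may bear on it.

Compound 1 `COc1ccc(C(=O)CSc2nnc(-c3cc(OC)c(OC)c(OC)c3)n2-c2ccc(OC)cc2)cc1`: > 60000 nM
Compound 2 `COc1cc(-c2nnc(SCC(=O)c3ccccc3)n2-c2ccc(N(C)C)cc2)cc(OC)c1OC`: 38600 nM

Both results come from a functional assay on PC-3 cells (Homo sapiens) for inhibition, read by MTT assay, with a stated time of 48 h; a lower number here means a stronger inhibitor, a higher number a weaker inhibitor. The entry for compound 1 is a limit of the assay and not a number. Among the compounds with values here, that leaves compound 2, at 38600 nM, with the only true number in this small set, so it is the sole numerical anchor for what follows.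

The next compound to be tested is compound 3 `COc1ccc(C(=O)CSc2nnc(-c3cc(OC)c(OC)c(OC)c3)n2-c2ccc(N(C)C)cc2)cc1`. It differs from compound 2 in one place: methoxy in place of hydrogen on an aromatic carbon. The methoxy takes the place of a hydrogen on an aromatic carbon of a six-membered aromatic ring of carbon only, para to a large group, which turns benzoyl into (4-methoxyphenyl)carbonyl.

Within the data shown here, no measured pair of compounds shows what this exact change does, so any forecast here is cautious. The estimated step of a 1.2-fold higher number from compound 2 to compound 3 (0.07 log units; within the scatter) is expected to be small, perhaps slightly toward weaker inhibition, and no larger than the usual scatter of repeated measurements. For compound 3, the expected value is 45000 nM, with an estimated range of 18000 nM to 60000 nM.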

Compound 3, half-maximal inhibitory concentration: 22000 nM
Beside the measured number, compound 3's estimate is 2.0-fold (0.31 log units) above it, within the range that was stated.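

In this assay the change from benzoyl to (4-methoxyphenyl)carbonyl now has a measured outcome: methoxy in place of hydrogen on an aromatic carbon, para to a large group, gives a 1.8-fold lower number from compound 2 to compound 3 (0.24 log units; within the scatter) and so leaves this pair indistinguishable in this read-out. Within the data shown here, the second comparison concerns a different place, since dimethylamino in place of methoxy on an aromatic carbon, with the (4-methoxyphenyl)carbonyl end left unchanged, gives an at least 2.7-fold lower number from compound 1 to compound 3 (0.43 log units; beyond the scatter) and is the only step here that exceeds the usual scatter. The entry for compound 1 is a limit and not a number, so this step gives only a minimum size: the limit of > 60000 nM in this assay, at which 1 of the 3 values shown sits.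

Still open, on these data alone, is whether a different group on the same aromatic carbon, such as a carboxylic acid, an amine or a longer ethoxy chain, would move the number beyond the scatter, where methoxy did not. Also open, as far as these compounds go, is how far dimethylamino truly shifts the number from methoxy, and whether a replacement such as a pyrrolidine ring or a plain amine at that place would give a comparable step.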